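Ring Contraction at the Chain Amine: Expecting Little Change

The source may hold more compounds than are shown below. What is called first, only, known or untested is meant among the compounds shown, and "the series" means these compounds.

Compound 3 `COc1cc(/C=C/C(=O)Nc2ccccc2)ccc1OCCCCN1CCCCC1` gives 1.61 in a physicochemical assay for lipophilicity, using the shake flask method, measured as octanol-water partition, at pH 7.4; a lower number here means a more polar compound, a higher number a more lipophilic compound. Its nearest neighbour, compound 2 `CCN(CC)CCCCOc1ccc(/C=C/C(=O)Nc2ccccc2)cc1OC`, gives 1.59, and the furthest, compound 1 `COc1cc(/C=C/C(=O)Nc2ccccc2)ccc1OCCCN(C)C`, gives 1.55; neither lies beyond the scatter of compound 3. The three measured steps all altered the amine at the end of the chain and none moved the partition coefficient beyond the scatter: a number 0.04 log units higher from compound 1 to compound 2 (within the scatter), a number 0.06 log units higher from compound 1 to compound 3 (within the scatter) and a number 0.02 log units higher from compound 2 to compound 3 (within the scatter).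

Compound 4 `COc1cc(/C=C/C(=O)Nc2ccccc2)ccc1OCCCCN1CCCC1` has not yet been measured. It differs from compound 3 in one place: pyrrolidin-1-yl in place of piperidin-1-yl on a saturated chain carbon, four bonds along the chain from an oxygen on an aromatic ring. The most direct comparison is a number 0.02 log units higher from compound 2 to compound 3 (within the scatter), where an open-chain amine was exchanged for the six-membered ring at the same place along the chain, and the two steps starting from compound 1 likewise stayed within the scatter. On that basis compound 4 is expected to show no step beyond the scatter in this assay, and the expected step of a number 0.16 log units lower from compound 3 to compound 4 (within the scatter) is a small downward one. The estimate for compound 4 is 1.45, with a range from 1.15 to 1.75.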

Compound 4, partition coefficient: 1.6
Estimate against measurement, compound 4: 0.15 log units below; the range from low to high includes it.
By their numbers in this assay, from the lowest: compounds 1, 2, 4 and 3 (each within the scatter of the next).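

In this assay, going by these compounds alone, the earlier compounds had tried only the six-membered ring and open-chain amines at this place, and contracting that ring gave a number 0.01 log units lower from compound 3 to compound 4 (within the scatter), so pyrrolidin-1-yl and piperidin-1-yl, on a saturated chain carbon four bonds along the chain from an oxygen on an aromatic ring, cannot be told apart here. The five-membered ring also cannot be separated from the open-chain amines, with pyrrolidin-1-yl in place of diethylamino giving a number 0.01 log units higher from compound 2 to compound 4 (within the scatter) and (pyrrolidin-1-yl)methyl in place of dimethylamino giving a number 0.05 log units higher from compound 1 to compound 4 (within the scatter), which leaves all four compounds within the scatter of one another in this assay. Nothing further is available to account for these results.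

The compounds shown leave open whether an amine end carrying a second hetero atom, such as morpholin-4-yl or piperazin-1-yl, or a primary amine, would also stay within the scatter of these four. They also leave open whether a carboxylic acid at the end of the chain, or a longer chain carrying pyrrolidin-1-yl, would give a step beyond the scatter.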